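The compounds below may be only part of what the source reports. "The series", "measured", "known", "first", "only" and "open" are said of these compounds alone.

Measured compounds:
compound 1 `CC(C)[C@H](NC(=O)COc1cccc2ccccc12)C(=O)N[C@@H](CC(=O)O)C(=O)COc1ccccc1` gives 11200 nM in a functional assay with Homo sapiens as the target; on this read-out higher numbers stand for weaker inhibition and lower numbers for stronger inhibition
compound 2 `CC(C)[C@H](NC(=O)COc1cccc2ccccc12)C(=O)N[C@@H](CC(=O)O)C(=O)COc1ccccc1[N+](=O)[O-]` gives 27700 nM
compound 3 `CC(C)[C@H](NC(=O)COc1cccc2ccccc12)C(=O)N[C@@H](CC(=O)O)C(=O)COc1ccc([N+](=O)[O-])cc1` gives 22800 nM

Compound 2 gives the highest of the three numbers in this assay; compound 3 sits within the scatter of it (a 1.2-fold lower number from compound 2 to compound 3 (0.08 log units; within the scatter)), while compound 1 lies a clear step below it (a 2.5-fold higher number from compound 1 to compound 2 (0.39 log units; beyond the scatter)). Compound 4 `CC(C)[C@H](NC(=O)COc1cccc2ccccc12)C(=O)N[C@@H](CC(=O)O)C(=O)COc1c(F)c(F)c(F)c(F)c1F` is reached from compound 2 by 2,3,4,5,6-pentafluorophenyl in place of 2-nitrophenyl on an oxygen on a saturated carbon. Among the compounds with values here, no measured step exchanges one substituted phenyl for another beyond the scatter: the move from compound 2 to compound 3 stayed within it, and the two nitro steps (a 2.5-fold higher number from compound 1 to compound 2 (0.39 log units; beyond the scatter), a 2.0-fold higher number from compound 1 to compound 3 (0.31 log units; beyond the scatter)) were modest rises. Within the data shown here, the only guidance is that the unsubstituted phenyl of compound 1 gave the lowest number, so compound 4 is expected to return toward that side, with the step of a 3.1-fold lower number from compound 2 to compound 4 (0.49 log units; beyond the scatter) carrying wide uncertainty. Compound 4 is therefore estimated at 9000 nM, in the range 2000 nM to 30000 nM.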

Compound 4, half-maximal inhibitory concentration: 8890 nM
Estimate against measurement, compound 4: 1.0-fold (0.01 log units) above, and the stated range covers the measured number.
By their numbers in this assay, from the lowest: compounds 4 and 1 (each within the scatter of the next); then compounds 3 and 2 (each within the scatter of the next).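

In this assay, the aromatic group on this oxygen can be heavily substituted without the number rising: a 3.1-fold lower number from compound 2 to compound 4 (0.49 log units; beyond the scatter) and a 2.6-fold lower number from compound 3 to compound 4 (0.41 log units; beyond the scatter) both go down, while a 1.3-fold lower number from compound 1 to compound 4 (0.10 log units; within the scatter) stays within the scatter. Substitution as such therefore does not set the number here, since among these compounds only the two nitrophenyl groups stand higher than phenyl, and 2,3,4,5,6-pentafluorophenyl does not. Nothing available explains this split.

Going by these compounds, it remains open how a single fluorine, a trifluoromethyl or a nitrile on the ring would behave, and whether an amine there would follow the nitro groups.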